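Replacing Diisopropylamino with Butylamino on a Chloro-Triazine Core

This account rests on a few compounds, and the source may have more. Where it says the series, first, only, none or still open, it means among the compounds named here.

Measured so far:
- Compound 1 `CNc1nc(Cl)nc(N[C@@H](C)c2ccccc2)n1`: 26900 nM
- Compound 2 `C[C@H](Nc1nc(Cl)nc(NC(C)(C)C)n1)c1ccccc1`: 7410 nM
- Compound 3 `CC(C)N(c1nc(Cl)nc(N[C@H](C)c2ccccc2)n1)C(C)C`: 6610 nM

All three compounds share a chloro-bearing core and differ only in the amino group that sits on the ring carbon between two ring nitrogen atoms. In an ADME assay on the whole organism for inhibition, with Echinochloa crus-galli var. formosensis as the target, with a stated time of 4 days (on this read-out lower numbers stand for stronger inhibition and higher numbers for weaker inhibition), compound 1 gives 26900 nM; compound 2 gives 7410 nM; compound 3 gives 6610 nM. Compound 3 has the lowest number of the three, but its gap to compound 2 lies within the scatter, so the two cannot be ranked; only compound 1 stands clearly apart, its gap to compound 3 lying beyond the scatter.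

Compound 4 `CCCCNc1nc(Cl)nc(N[C@H](C)c2ccccc2)n1` has not yet been measured. It arises from compound 3 by butylamino in place of diisopropylamino on an aromatic carbon.

Among the compounds with values here, one measured step bears on this: a 3.6-fold lower number from compound 1 to compound 2 (0.56 log units; beyond the scatter). That step shows that enlarging the group on this nitrogen from methyl to a four-carbon group lowered the number modestly. Compound 4 also carries a four-carbon group with one hydrogen-bond donor, as compound 2 does, so a number close to those of compound 2 and compound 3 is expected, and the step of a 1.4-fold higher number from compound 3 to compound 4 (0.13 log units; within the scatter) is expected to stay near or within the scatter. The estimate for compound 4 in this assay is 9000 nM, with a range from 3500 nM to 24000 nM.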

Compound 4, half-maximal inhibitory concentration: 38900 nM
Compound 4: the middle estimate sits 4.3-fold (0.64 log units) below what was measured; the measured number lies above the stated range.
By their numbers in this assay, from the lowest: compounds 3 and 2 (each within the scatter of the next); then compounds 1 and 4 (each within the scatter of the next).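

In this assay, the change gives a 5.9-fold higher number from compound 3 to compound 4 (0.77 log units; beyond the scatter), so this position does not reward a larger group in any simple way: the earlier step, a 3.6-fold lower number from compound 1 to compound 2 (0.56 log units; beyond the scatter), could have suggested that it did. Among the four compounds, the branched groups on compound 2 and compound 3 go with the lower numbers, whereas the unbranched butylamino of compound 4 lands with the much smaller methylamino group of compound 1, within the scatter of it. Hydrogen-bond donor count does not sort these results on its own, since compound 2 keeps the amino hydrogen that compound 3 lacks and still has a number within the scatter of compound 3, and no measurement here explains the link with branching.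

Four compounds cannot show whether branching itself matters or only the particular groups tested. An isopropylamino or sec-butylamino group would help separate those readings, while a longer chain such as hexylamino would show whether unbranched groups stay weak as they grow.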